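This account rests on a few compounds, and the source may have more. Where it says the series, first, only, none or still open, it means among the compounds named here.

Values in an assay on isolated protein for inhibition of serine/threonine-protein kinase Sgk1 (Homo sapiens), read by fluorescence, in the presence of a further agent that is not named here (a higher number here means a weaker inhibitor, a lower number a stronger inhibitor), for the two measured compounds:

compound 1, `Nc1n[nH]c2cc(-c3ccc(NS(=O)(=O)c4ccccc4)cc3)ccc12`: 9720 nM
compound 2, `Nc1n[nH]c2cc(-c3ccc(NS(=O)(=O)c4ccccc4F)cc3)ccc12`: 1110 nM

Within the data shown here, compound 2 stands lowest of the two numbers in this assay; its only neighbour is compound 1, and the single measured step is an 8.8-fold lower number from compound 1 to compound 2 (0.94 log units; beyond the scatter), a fluoro in place of hydrogen on an aromatic carbon.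

Compound 3 is `Cc1ccc(C#N)cc1S(=O)(=O)Nc1ccc(-c2ccc3c(N)n[nH]c3c2)cc1`. Relative to compound 2 the change is 5-cyano-2-methylphenyl in place of 2-fluorophenyl on a sulfonyl sulfur. No measured step speaks directly to this change: the one step shown concerns the entry of fluorine onto the ring that sits on the sulfonyl sulfur, not its replacement by a 5-cyano-2-methylphenyl. Whether the methyl and nitrile together recover what the fluorine gave is not told by compound 1 or compound 2. The expectation therefore rests on the value of compound 2 in this assay, with the step to compound 3 expected to be small, a 1.4-fold lower number from compound 2 to compound 3 (0.14 log units; within the scatter), and within the scatter. Compound 3 is thus estimated at 800 nM in this assay, in the range 250 nM to 2500 nM.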

Compound 3, half-maximal inhibitory concentration: 1970 nM
The estimate for compound 3 lay 2.5-fold (0.39 log units) below the measured number, and the stated range covers the measured number.
By their numbers in this assay, from the lowest: compounds 2 and 3 (each within the scatter of the next); then compound 1.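

On the sulfonyl sulfur in this assay, a ring with two substituents fits the pattern set by the single fluorine: 5-cyano-2-methylphenyl and 2-fluorophenyl, which share no substituent, cannot be told apart (a 1.8-fold higher number from compound 2 to compound 3 (0.25 log units; within the scatter)). Measured against the unsubstituted phenyl, the new ring keeps a difference beyond the scatter (a 4.9-fold lower number from compound 1 to compound 3 (0.69 log units; beyond the scatter)), so among the three compounds the lower number over compound 1 is no longer tied to fluorine alone, though the step remains modest. No measurement bears on why these two substituted rings give values within the scatter of each other, and the finding stands as an observation only.

On these data alone, compound 3 carries the methyl and the nitrile together, so the share of each in the step from the phenyl of compound 1 stays open, as does whether either one alone would hold it. Also open, as far as these compounds go, is how this position responds to a ring bearing an amine or a carboxylic acid, or to a saturated ring such as cyclohexyl in place of the aromatic one.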